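This account rests on a few compounds, and the source may have more. Where it says the series, first, only, none or still open, it means among the compounds named here.

Measured compounds:
compound 1, `ClCc1ccccc1Cn1cnc2c(Cl)nc(Cl)nc21`, 150 nM
compound 2, `ClCc1cccc(Cn2cnc3c(Cl)nc(Cl)nc32)c1`, 1580 nM
compound 3, `Nc1nc(Cl)c2ncn(Cc3ccccc3CCl)c2n1`, 3310 nM

Values are from a functional assay on SW-620 cells (Homo sapiens) for cytotoxicity, read by sulforhodamine B assay, with a stated time of 48 h; a higher number here means a weaker inhibitor of growth, a lower number a stronger inhibitor of growth. Compound 1 stands lowest of the three. The difference between the core of compound 1 and that of compound 2, the same atoms joined differently, is not broken down here; compound 2 gives the middle number, and compound 3 the highest.

Compounds 1 and 3 differ in one place: amino in place of chloro on an aromatic carbon. The step is a 22-fold higher number from compound 1 to compound 3 (1.34 log units; beyond the scatter), a large move toward weaker growth inhibition in this assay.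

Compound 4, `Nc1nc(Cl)c2ncn(Cc3cccc(CCl)c3)c2n1`, is not yet measured. It stands to compound 2 as compound 3 stands to compound 1: amino in place of chloro on an aromatic carbon. The place line is the same word for word in both pairs, so this is the same change made on the other core.

For the measured compounds named here, the expectation for compound 4 rests on compound 1 and compound 3, because a 22-fold higher number from compound 1 to compound 3 (1.34 log units; beyond the scatter) is the only measured instance of this change. Going by the values given here, the step expected from compound 2 is a 14-fold higher number from compound 2 to compound 4 (1.14 log units; beyond the scatter), set beside the earlier step but taken somewhat less steep, since only one example is known. Compound 4 is thus estimated at 22000 nM in this assay, between 6000 nM and 70000 nM.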

Compound 4, concentration for 50% growth inhibition: 3800 nM
For compound 4 the middle estimate is 5.8-fold (0.76 log units) above the measured one; the whole stated range lies above it.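

Amino in place of chloro on an aromatic carbon moves the number the same way on both cores in this assay, toward weaker growth inhibition, and the new step is a 2.4-fold higher number from compound 2 to compound 4 (0.38 log units; beyond the scatter), modest in size. Across these two pairs the direction of the change carries from one core to the other, but its size does not: the same change on two cores in this assay, a 22-fold higher number (1.34 log units; beyond the scatter) from compound 1 to compound 3 and a 2.4-fold higher number (0.38 log units; beyond the scatter) from compound 2 to compound 4, 9.2-fold (0.96 log units) apart, beyond the scatter of two such steps

The size of this change therefore depends on the core that carries it, but two pairs do not show which feature of the core sets that size, nor whether the shared direction would hold on any further core.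

The compounds shown leave open whether a methylamino, methoxy or hydroxyl group on the same aromatic carbon would follow amino in direction and in size on each core. Also open, as far as these compounds go, is how either core would respond if a hydroxymethyl or bromomethyl group took the place of the chloromethyl group.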